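Cyclopentenyl in place of oxazolyl on the chlorophenyl arm

The compounds below may be only part of what the source reports. "The series", "measured", "known", "first", "only" and "open" are said of these compounds alone.

Among the measured compounds shown here, compound 2 `Cn1nc2c(=O)n(CC3(O)CCN(Cc4ccc(-c5ncco5)cc4Cl)CC3)cnc2c1-c1ccc(CN)cc1` gives 1120 nM in an assay on isolated protein for inhibition of ubiquitin carboxyl-terminal hydrolase 7 (Homo sapiens), with stated times of 30 min and 2 h (a lower number here means a stronger inhibitor, a higher number a weaker inhibitor), the lowest of the two numbers so far; compound 1 `Cn1nc2c(=O)n(CC3(O)CCN(Cc4ccc(C5CCCO5)cc4Cl)CC3)cnc2c1-c1ccc(CN)cc1` gives 3820 nM, and a 3.4-fold lower number from compound 1 to compound 2 (0.53 log units; beyond the scatter). Compound 3 `Cn1nc2c(=O)n(CC3(O)CCN(Cc4ccc(C5=CCCC5)cc4Cl)CC3)cnc2c1-c1ccc(CN)cc1` carries the change (cyclopent-1-en-1-yl in place of 1,3-oxazol-2-yl on an aromatic carbon). For the measured compounds named here, only the step from compound 1 to compound 2 bears on this, and it ran towards a five-membered aromatic ring with two hetero atoms; compound 3 returns to a five-membered non-aromatic ring, now of carbon only, so part of that gain is expected to be given back. The expected step is therefore a 2.2-fold higher number from compound 2 to compound 3 (0.35 log units; beyond the scatter), towards a weaker number. Compound 3 is estimated at 2500 nM, range 1000 nM to 6500 nM.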

Compound 3, half-maximal inhibitory concentration: 76.9 nM
For compound 3 the middle estimate is 33-fold (1.51 log units) above the measured one; measured number below the stated range.
By their numbers in this assay, from the lowest: compound 3; then compound 2; then compound 1.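

In this assay this position takes cyclopent-1-en-1-yl far better than either earlier group: a 15-fold lower number from compound 2 to compound 3 (1.16 log units; beyond the scatter) and a 50-fold lower number from compound 1 to compound 3 (1.70 log units; beyond the scatter). Both earlier rings carry hetero atoms, yet the ring of carbon only gives the lowest number of the three, so hydrogen-bond acceptors on this ring are not required for inhibition in this set. No available evidence accounts for the size of these steps. From the compounds shown here alone, whether the double bond or the all-carbon ring drives the gain remains open; a cyclopentyl group or a phenyl group here would separate the two.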